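A few compounds are considered here, and "the series" means these few. Any claim that something is new, unique, unknown or untested is made for them only; others in the source may bear on it.

Measured compounds in a toxicity assay on WI-38 cells (Homo sapiens) for cytotoxicity, read by MTT assay, with a stated time of 48 h; on this read-out higher numbers stand for weaker inhibition and lower numbers for stronger inhibition:
Compound 1 `O=C(/C=C/c1ccc2c(c1)B(O)OC2)c1ccccc1` gives 19100 nM.
Compound 2 `O=C(/C=C/c1ccc2c(c1)B(O)OC2)c1cccs1` gives 26000 nM.
Compound 3 `O=C(/C=C/c1ccc2c(c1)B(O)OC2)c1ccccc1O` gives > 100000 nM, which is a limit of the assay and not a number.

All three share the same core and differ only in the group on the carbonyl carbon. Compound 3 sits at the weak end of what was measured: of the three values, it is the one that reached the assay limit (the limit of > 100000 nM in this assay, at which 1 of the 3 values shown sits). The steps of a 1.4-fold higher number from compound 1 to compound 2 (0.13 log units; within the scatter) and an at least 5.2-fold higher number from compound 1 to compound 3 (0.71 log units; beyond the scatter) show that swapping phenyl for thiophen-2-yl changed little, while adding the hydroxy pushed the number out of the measurable range; the step of an at least 3.8-fold higher number from compound 2 to compound 3 (0.58 log units; beyond the scatter) points the same way.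

Compound 4 `COCOc1ccccc1C(=O)/C=C/c1ccc2c(c1)B(O)OC2` carries methoxymethyl in place of hydrogen on an oxygen on an aromatic ring. Going by the values given here, no measured step covers this exact change. Among the compounds with values here, the only related evidence comes from compound 1 and compound 3. Compound 1, without the hydroxy, gives 19100 nM. Compound 3, with the hydroxy, reached only a limit of the assay. Capping the hydroxy may move compound 4 back toward compound 1, but a weaker number is also possible. The expected step is therefore an at least 2.0-fold lower number from compound 3 to compound 4 (0.30 log units; that floor lies within the scatter), with wide uncertainty. For compound 4 the estimate in this assay is 50000 nM, ranging from 15000 nM to 200000 nM.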

Compound 4, half-maximal inhibitory concentration: 27000 nM
Compound 4: middle estimate off by 1.9-fold (0.27 log units), on the high side, within the range that was stated.
By their numbers in this assay, from the lowest: compounds 1, 2 and 4 (each within the scatter of the next). At a limit, above all of these: compound 3.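

In this assay, putting methoxymethyl on the oxygen on the aromatic ring gives an at least 3.7-fold lower number from compound 3 to compound 4 (0.56 log units; beyond the scatter). This shows that the free hydroxy, with its hydrogen, goes with the high number in this small set, and that an oxygen attached at this place does not by itself bring that number. The comparison with the compound that has no oxygen group here gives a 1.4-fold higher number from compound 1 to compound 4 (0.15 log units; within the scatter), so the larger methoxymethoxy group leaves the number within the scatter of plain hydrogen on an aromatic carbon, and only the hydroxy compound stands apart: the limit of > 100000 nM in this assay, at which 1 of the 4 values shown sits.

The compounds shown leave open how far this tolerance reaches, for example whether a simple methoxy, a longer chain on the same oxygen, or an amine in place of the hydroxy would also stay close to compound 1 or would move toward compound 3. Going by these compounds, it is also open whether a hydroxy or a methoxymethoxy would act the same way on the thiophen-2-yl group of compound 2, since both changes are seen here only on the phenyl group.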